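Swapping an acetyl for a 2-chlorobenzoyl on the ring nitrogen

A few compounds are considered here, and "the series" means these few. Any claim that something is new, unique, unknown or untested is made for them only; others in the source may bear on it.

Measured so far:
- compound 1, `COc1ccc(NC(=O)C2CCc3ccccc3N2)cc1`, 56900 nM
- compound 2, `O=C(Nc1ccccc1O)C1CCc2ccccc2N1`, 4310 nM
- compound 3, `CC(=O)N1c2ccccc2CCC1C(=O)Nc1cc(C(F)(F)F)cc(C(F)(F)F)c1`, > 70000 nM

The three compounds share a core, and all were tested in a functional assay on PC-3 cells (Homo sapiens) for cytotoxicity, read by sulforhodamine B assay, with a stated time of 72 h; a higher number here means a weaker inhibitor of growth, a lower number a stronger inhibitor of growth. Compound 1 gives 56900 nM and compound 2 gives 4310 nM. For compound 3 the result is only a limit of the assay, > 70000 nM, so no number is known for it. This is the case described by the limit of > 70000 nM in this assay, at which 1 of the 3 values shown sits. Among the values shown, compound 3 therefore sits at the weak end, with no measured growth inhibition within the tested range.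

Compound 4, `O=C(Nc1cc(C(F)(F)F)cc(C(F)(F)F)c1)C1CCc2ccccc2N1C(=O)c1ccccc1Cl`, is not yet measured in this assay. It differs from compound 3 in one place: 2-chlorophenyl in place of methyl on a carbonyl carbon. Within the data shown here, no step between two measured compounds isolates this kind of change, so there is no direct guide to its size or direction. The only anchor is the limit of compound 3. The step from compound 3 to compound 4 is expected to be small, an at least 1.5-fold lower number from compound 3 to compound 4 (0.19 log units; that floor lies within the scatter), and it may well not lift compound 4 clearly out of the range where the assay reports only a limit. Compound 4 is therefore expected to give about 45000 nM, within a range from 10000 nM to 70000 nM.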

Compound 4, concentration for 50% growth inhibition: 8040 nM
For compound 4 the middle estimate is 5.6-fold (0.75 log units) above the measured one; measured number outside the range, below it.
By their numbers in this assay, from the lowest: compounds 2 and 4 (each within the scatter of the next); then compound 1. At a limit, above all of these: compound 3.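

The change from acetyl to (2-chlorophenyl)carbonyl, made at a carbonyl carbon on an amide-type nitrogen in a ring, gives in this assay an at least 8.7-fold lower number from compound 3 to compound 4 (0.93 log units; beyond the scatter), and this is the only step among the compounds shown that can be read as a change in one place. It shows that the group at this position matters for growth inhibition: with 2-chlorophenyl in place of methyl, the compound moves from a result reported only as a limit to a measured value. The true size of the step stays unknown, because the result for compound 3 is a limit and not a number: the limit of > 70000 nM in this assay, at which 1 of the 4 values shown sits.

The compounds shown leave open whether the lower number comes from the aromatic ring itself or from its chlorine, and a plain phenyl on the same carbonyl carbon would separate the two. They also leave open whether a ring is needed at all, which a cyclohexyl or a longer chain with an amine at this position could help to answer.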